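From furan-2-yl to phenyl on a shared core

The source may hold more compounds than are shown below. What is called first, only, known or untested is meant among the compounds shown, and "the series" means these compounds.

Measured in an ADME assay on BJ cells (Homo sapiens), read by MTT assay, with a stated time of 72 h; a higher number here means a weaker inhibitor, a lower number a stronger inhibitor:
Compound 1 `COc1ncnc2c1c(-c1ccccc1)cn2[C@@H]1O[C@H](CO)[C@@H](O)[C@H]1O`: > 100000 nM
Compound 2 `Nc1nc2c(c(-c3ccco3)cn2[C@@H]2O[C@H](CO)[C@@H](O)[C@H]2O)c(=O)[nH]1`: > 100000 nM

Both entries are limits of the assay, not numbers. Compound 2 sits at the limit of > 100000 nM in this assay, at which 2 of the 2 values shown sit, so no exact figure is known for it.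

Compound 3 `Nc1nc2c(c(-c3ccccc3)cn2[C@@H]2O[C@H](CO)[C@@H](O)[C@H]2O)c(=O)[nH]1` keeps the core of compound 2 and changes one group, with phenyl in place of furan-2-yl on an aromatic carbon. Within the data shown here, no measured pair shows this change directly. Compound 1 also carries a phenyl, and its result is the limit > 100000 nM. On that basis, no shift beyond the usual scatter is expected in this assay, and the estimated step is a number no higher from compound 2 to compound 3 (the limit leaves the size open). Compound 3 is expected at about 100000 nM, with an estimated range from 40000 nM to 150000 nM, and it may well be reported only as a limit.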

Compound 3, half-maximal inhibitory concentration: > 100000 nM
Compound 3: no number, only a limit; the forecaster's own chance of this, stated with the estimate: 80%; the middle value sits exactly at the limit.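

Compound 3 is reported in this assay only as a limit, > 100000 nM, so the change from furan-2-yl to phenyl between compound 2 and compound 3 cannot be read as a step. The compounds shown leave open whether any change on the shared core would give an exact value: the limit of > 100000 nM in this assay, at which 3 of the 3 values shown sit.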